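Ester Variation on a Furyl Dihydropyrimidinone Scaffold

The source may report more compounds than this note shows. Statements on the series, on what has been measured and on what is new or still open speak of the compounds shown alone.

Going by the values given here, compound 2 `CC1=C(C(=O)OC2CCCC2)C(c2ccoc2)NC(=O)N1` gives 1010 nM in an assay on membranes from HEK293 cells for displacement of a labelled ligand from adenosine receptor A2b (Homo sapiens), read by scintillation counting, with a stated time of 30 min (on this read-out lower numbers stand for stronger inhibition and higher numbers for weaker inhibition), the highest of the two numbers so far; the nearest is compound 1 `CCC(C)OC(=O)C1=C(C)NC(=O)NC1c1ccoc1`, which gives 201 nM in this assay. Among the compounds with values here, the one step available, a 5.0-fold higher number from compound 1 to compound 2 (0.70 log units; beyond the scatter), arose from cyclopentyl in place of sec-butyl on an oxygen next to a carbonyl group. Compound 3 `CC1=C(C(=O)OCC2CCC2)C(c2ccoc2)NC(=O)N1` differs from compound 2 by cyclobutylmethyl in place of cyclopentyl on an oxygen next to a carbonyl group. Since that step was modest and the ester group again keeps five carbons, compound 3 is expected to give a step of a 1.7-fold lower number from compound 2 to compound 3 (0.23 log units; within the scatter), a small downward move not clearly beyond the scatter. The estimate for compound 3 is 600 nM, ranging from 200 nM to 1800 nM.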

Compound 3, inhibition constant: 739 nM
Compound 3: middle estimate off by 1.2-fold (0.09 log units), on the low side; the range from low to high includes it.
By their numbers in this assay, from the lowest: compound 1; then compounds 3 and 2 (each within the scatter of the next).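

In this assay, cyclobutylmethyl in place of cyclopentyl gives a 1.4-fold lower number from compound 2 to compound 3 (0.14 log units; within the scatter), so moving from a five-membered to a four-membered ring with the same carbon count separates nothing at this position. Cyclobutylmethyl in place of sec-butyl gives a 3.7-fold higher number from compound 1 to compound 3 (0.57 log units; beyond the scatter), so among these three esters, compound 1, the only one without a ring, stands apart from both ring-bearing esters. Nothing available explains this difference.
As far as these compounds go, whether a longer chain or an amine on this oxygen would bring the number closer to that of compound 1 remains open.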